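From 2-fluorobenzyl to 3-fluorobenzyl: compound 3 and compound 4

The compounds below may be only part of what the source reports. "The series", "measured", "known", "first", "only" and "open" are said of these compounds alone.

Measured in a functional assay on GBM3 cells (Homo sapiens) for antiproliferative activity, read by WST assay, with a stated time of 72 h; on this read-out lower numbers stand for stronger inhibition and higher numbers for weaker inhibition:
- Compound 1 `O=C(Nc1cccc(Cl)c1)Nc1cc2ncncc2cc1OCc1ccccc1Cl`: 2800 nM
- Compound 2 `O=C(Nc1ccc(C(F)(F)F)cc1)Nc1cc2ncncc2cc1OCc1cccc(F)c1`: 6300 nM
- Compound 3 `O=C(Nc1ccc(Cl)c(Cl)c1)Nc1cc2ncncc2cc1OCc1ccccc1F`: > 10000 nM (a limit of the assay, not a number)

Compound 3 stands at the limit of > 10000 nM in this assay, at which 1 of the 3 values shown sits. From the compounds shown here alone, how weak it really is stays unknown.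

Compound 4 `O=C(Nc1ccc(Cl)c(Cl)c1)Nc1cc2ncncc2cc1OCc1cccc(F)c1` has 3-fluorophenyl in place of 2-fluorophenyl on a saturated chain carbon bound to an oxygen on an aromatic ring. Among the measured compounds shown here, no measured pair of compounds shows the size of this change. The nearest guide is loose: compound 2, which also carries 3-fluorophenyl at that place but differs elsewhere, gives 6300 nM. What is expected in this assay is therefore a small move towards stronger inhibition, an at least 1.4-fold lower number from compound 3 to compound 4 (0.15 log units; that floor lies within the scatter), and a reading that again stops at the limit would be no surprise. For compound 4 the estimated value is 7000 nM. The expected range for it runs from 2500 nM to 15000 nM.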

Compound 4, half-maximal inhibitory concentration: 2000 nM
Compound 4: middle estimate off by 3.5-fold (0.54 log units), on the high side; the whole stated range lies above it.
By their numbers in this assay, from the lowest: compounds 4 and 1 (each within the scatter of the next); then compound 2. At a limit, above all of these: compound 3.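

In this assay, among the compounds shown here, 3-fluorobenzyl in place of 2-fluorobenzyl, with the 3,4-dichlorophenyl group kept, gives an at least 5.0-fold lower number from compound 3 to compound 4 (0.69 log units; beyond the scatter), which is the first direct reading of this change on a saturated chain carbon bound to an oxygen on an aromatic ring. From the compounds shown here alone, the reading of compound 3 is a limit of the assay and not a number, and the full size of this step stays unknown: the limit of > 10000 nM in this assay, at which 1 of the 4 values shown sits. With 3-fluorobenzyl kept, 3,4-dichlorophenyl in place of 4-(trifluoromethyl)phenyl on an amide-type nitrogen gives a 3.2-fold lower number from compound 2 to compound 4 (0.50 log units; beyond the scatter), so the group at that second place also changes the reading.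

For the compounds shown here, only one pair shows the fluorine change, and whether it holds with other groups on the amide-type nitrogen remains open. Going by these compounds, how a methoxy group or an amine in place of the fluorine would read in this assay is also open.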